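Working notes on cytotoxicity: from compound 1 to compound 3

This account rests on a few compounds, and the source may have more. Where it says the series, first, only, none or still open, it means among the compounds named here.

Measured so far:
- compound 1 `CCCCCCCCCO[C@@H]1[C@@H](N)[C@@H](OCC(O)CNCCCO)O[C@H](CN)[C@H]1OCCCCCCCCC`: in a toxicity assay on the whole organism (J774 cells) for cytotoxicity, with Mus musculus as the target, read by MTT assay, with a stated time of 24 h, tested at 10 uM (a higher number here means a weaker effect of the compound at the concentration tested, a lower number a stronger effect), compound 1 gives 89.9%
- compound 2 `NC[C@H]1O[C@H](O[C@H]2[C@H](O)[C@@H](O)[C@H](N)C[C@@H]2N)[C@H](N)[C@@H](OCCCc2ccc3ccccc3c2)[C@@H]1OCCCc1ccc2ccccc2c1`: in this assay compound 2 gives 87.7%

Compound 1 holds the highest of the two numbers shown; its nearest neighbour is compound 2, lower by a difference that lies within the scatter of the method, so the two readings cannot be put in order. Compound 3 `CCCCCCCCCO[C@@H]1[C@@H](N)[C@@H](OCC(O)CNCCCN)O[C@H](CN)[C@H]1OCCCCCCCCC` has not yet been measured in this assay. It differs from compound 1 by amino in place of hydroxy on a saturated chain carbon, three bonds along the chain from an amine nitrogen. Among the compounds with values here, no step between two measured compounds is available to calibrate a change of this kind, and the two measured compounds themselves give no spread beyond the scatter. The expectation is therefore a step of no size beyond the scatter, a number 1.9 percentage points lower from compound 1 to compound 3 (within the scatter). For compound 3 the estimated value in this assay is 88%, with a range from 74% to 98%.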

Compound 3, a percentage reported as activity, at one concentration (the size of the read-out at that concentration, not a potency): 101%
Compound 3: the middle estimate sits 13 percentage points below what was measured, outside the stated range (above it).
By their numbers in this assay, from the lowest: compounds 2 and 1 (each within the scatter of the next); then compound 3.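

In this assay amino in place of hydroxy on a saturated chain carbon, three bonds along the chain from an amine nitrogen, gives a number 11.1 percentage points higher from compound 1 to compound 3 (beyond the scatter) and so weakens the effect at the concentration tested. This position therefore responds to the change, even though the computed counts of hydrogen-bond donors and acceptors and the net charge stay the same between the two groups; it is a single modest step from a single pair. Nothing at hand accounts for the step.

On these data alone, it remains open whether a methoxy or a dimethylamino group at this place would read like the hydroxy or the amino group. Also open, as far as these compounds go, is whether a longer chain carrying the terminal amine would extend the step or leave it unchanged.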